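Removing one methyl from the benzoxazine of compound 1

The source may report more compounds than this note shows. Statements on the series, on what has been measured and on what is new or still open speak of the compounds shown alone.

Measured so far:
compound 1 `Cc1cc(C)c2c(c1)CN(c1ccc3c(=O)cc(-c4ccccc4)oc3c1)CO2` — "not active" (no number reported)
compound 2 `COc1cc2c(c(OC)c1)OCN(c1ccc3oc(-c4ccccc4)cc(=O)c3c1)C2` — 60%

In a functional assay on MCF7 cells (Homo sapiens) for inhibition, read by MTT assay, with a stated time of 48 h, tested at 15 ug/mL (on this read-out lower numbers stand for less inhibition of growth and higher numbers for more inhibition of growth at the one concentration tested), compound 1 gives "not active" (no number reported), so no single number places it; compound 2 gives 60% in this assay. Among the compounds with values here, no pairwise step is recorded, and compound 2 differs from compound 1 in more than one place, so only the two readings themselves can be compared.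

Compound 3 `Cc1cccc2c1OCN(c1ccc3c(=O)cc(-c4ccccc4)oc3c1)C2` differs from compound 1 by hydrogen in place of methyl on an aromatic carbon. With compound 1 reported without a number, no change beyond the usual scatter is expected from this change alone. Compound 3 is expected to give 20%, within 0% to 50%.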

Compound 3, percent growth inhibition at one concentration: 54.9%
For compound 3 the middle estimate is 34.9 percentage points below the measured one; measured number above the stated range.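

Within the data shown here, compound 1 carries no number, and no step from it to compound 3 can be read. The compounds shown leave open how large a change in growth inhibition goes with removing this methyl. No evidence on a cause is at hand.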